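Removing a Ring Methyl from a Urea Lipoxygenase Inhibitor

The source may report more compounds than this note shows. Statements on the series, on what has been measured and on what is new or still open speak of the compounds shown alone.

Compound 1 `Cc1cc(OCc2nc3ccccc3s2)ccc1NC(=O)Nc1ccc(Cl)cc1` — 570 nM
Compound 2 `Cc1cc(OCc2nc3ccccc3s2)ccc1NC(=O)Nc1cc(Cl)cc(Cl)c1` — 80 nM

In an assay on isolated protein for inhibition of Polyunsaturated fatty acid 5-lipoxygenase (Homo sapiens), read by HPLC, with a stated time of 10 min (on this read-out higher numbers stand for weaker inhibition and lower numbers for stronger inhibition), compound 2 gives the lower of the two numbers, and the step of a 7.1-fold lower number from compound 1 to compound 2 (0.85 log units; beyond the scatter) separates it from compound 1. Compound 3 `O=C(Nc1ccc(OCc2nc3ccccc3s2)cc1)Nc1cc(Cl)cc(Cl)c1` differs from compound 2 by hydrogen in place of methyl on an aromatic carbon. Within the data shown here, no measured step bears on this change; the only known step concerns the chlorinated phenyl ring on the urea, not the shared core. With nothing pointing either way, the expected step is a 1.4-fold higher number from compound 2 to compound 3 (0.14 log units; within the scatter), not beyond the scatter. Compound 3 is therefore estimated at 110 nM in this assay, with a range from 45 nM to 300 nM.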

Compound 3, half-maximal inhibitory concentration: 90 nM
Beside the measured number, compound 3's estimate is 1.2-fold (0.09 log units) above it; the range from low to high includes it.
By their numbers in this assay, from the lowest: compounds 2 and 3 (each within the scatter of the next); then compound 1.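

In this assay, hydrogen in place of methyl on this aromatic carbon gives a 1.1-fold higher number from compound 2 to compound 3 (0.05 log units; within the scatter), so the methyl group makes no measurable difference to the number here. The earlier step concerned only the chlorinated phenyl ring, whereas this one shows that the ring bearing the methyl can also change without a measurable shift, at least alongside the 3,5-dichlorophenyl group. Nothing measured here gives a reason for this result.
Going by these compounds, whether a larger group on the same carbon, such as ethyl or methoxy, would also leave the number unchanged stays open. So does whether the same swap would behave alike with the 4-chlorophenyl group of compound 1.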